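A few compounds are considered here, and "the series" means these few. Any claim that something is new, unique, unknown or untested is made for them only; others in the source may bear on it.

Measured so far:
compound 1, `O=C(NCCCn1ccc(=O)[nH]c1=O)C(c1ccccc1)c1ccccc1`, 18000 nM;
compound 2, `O=c1ccn(CCCCNC(c2ccccc2)c2ccccc2)c(=O)[nH]1`, 99000 nM;
compound 3, `O=C(O)CCCn1ccc(=O)[nH]c1=O`, 18000 nM.

In an ADME assay on L6 cells (Rattus norvegicus) for cytotoxicity, read by resazurin assay, with a stated time of 72 h (a higher number here means that more compound is needed for the effect, a lower number that less compound is needed), compound 1 stands level with compound 3 at the digits shown, and the two together give the lowest numbers of the three; the gap from compound 1 to compound 2 is beyond the scatter, with compound 2 needing more compound for the effect. Compound 4, `O=C(NCCCO)C(c1ccccc1)c1ccccc1`, differs from compound 1 by the change (one oxygen atom in place of a group of 8 heavy atoms (4 carbon, 2 nitrogen, 2 oxygen; one six-membered aromatic ring with 2 hetero atoms), on a saturated chain carbon, three bonds along the chain from an amide-type nitrogen). Going by the values given here, no pair of measured compounds differs in just one place, so there is no measured step to lean on. A change of this kind is expected to move this assay little, if at all beyond the scatter, perhaps toward a somewhat higher number. Compound 4 is therefore estimated at 25000 nM, within 8000 nM to 80000 nM, meaning an expected step of a 1.4-fold higher number from compound 1 to compound 4 (0.14 log units; within the scatter).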

Compound 4, half-maximal effective concentration: 18000 nM
Estimate against measurement, compound 4: 1.4-fold (0.14 log units) above; the range from low to high includes it.
By their numbers in this assay, from the lowest: compounds 1, 3 and 4 (each within the scatter of the next); then compound 2.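

In this assay, going by these compounds alone, the hydroxy group takes the place of the group of 8 heavy atoms, with its six-membered aromatic ring with 2 hetero atoms, on a saturated chain carbon, three bonds along the chain from an amide-type nitrogen, and the outcome is no change at the digits printed from compound 1 to compound 4 (within the scatter) as the first measured step at this position. Here, then, the ring-bearing group is not needed for the number that compound 1 gives. On these data alone, whether an amine, a carboxylic acid or a longer chain at this place would leave that number unmoved stays open. No measurement at hand gives a reason for this result.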